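Fluoropyridine for Fluorophenyl in a Potassium Channel Opener Series

This account rests on a few compounds, and the source may have more. Where it says the series, first, only, none or still open, it means among the compounds named here.

Compound 1 `Cc1cc(NC(=O)Cn2nnc(-c3ccc(F)cc3)n2)n(C2CCCCC2)n1`: 92%
Compound 2 `Cc1cc(NC(=O)Cn2nnc(-c3ccccc3F)n2)n(C2CCCCC2)n1`: 88%

In an assay on HEK293 cells for activation of Kir3.1/Kir3.2 (Homo sapiens), read by thallium flux (on this read-out higher numbers stand for larger maximal responses and lower numbers for smaller maximal responses), compound 1 gives 92% and compound 2 gives 88%. Compound 2 stands right beside compound 1 on these numbers, and a number 4 percentage points lower from compound 1 to compound 2 (within the scatter), so the two are not told apart. Compound 3 `Cc1cc(NC(=O)Cn2nnc(-c3ccnc(F)c3)n2)n(C2CCCCC2)n1` differs from compound 2 by 2-fluoropyridin-4-yl in place of 2-fluorophenyl on an aromatic carbon. Within the data shown here, no measured step exchanges a carbon-only ring for a ring with one hetero atom, so the single measured step gives no direct guidance; it only shows that the two known compounds lie close together. Compound 3 is therefore expected to reach about 84%, from 62% to 100%, meaning an expected step of a number 4 percentage points lower from compound 2 to compound 3 (within the scatter), not beyond the scatter.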

Compound 3, largest response reached (Emax), in percent of the reference or control that the assay uses: 95%
For compound 3 the middle estimate is 11 percentage points below the measured one; measured number inside the range.
By their numbers in this assay, from the lowest: compounds 2, 1 and 3 (each within the scatter of the next).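

In this assay there is a number 7 percentage points higher from compound 2 to compound 3 (within the scatter) and a number 3 percentage points higher from compound 1 to compound 3 (within the scatter) when 2-fluoropyridin-4-yl takes the place of a fluorophenyl group. At this aromatic carbon of the five-membered aromatic ring with 4 nitrogen, a ring of carbon only can therefore give way to a ring with 1 hetero atom and 1 hydrogen-bond acceptor without a shift beyond the scatter. No measurement shown accounts for this result.

The compounds shown leave open whether the ring nitrogen or the fluorine matters more. They also leave open whether an amine or a carboxylic acid on this ring would keep the response.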